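Nitrophenyl placement on the shared core

The source may report more compounds than this note shows. Statements on the series, on what has been measured and on what is new or still open speak of the compounds shown alone.

Compound 3 `O=C1N=C(C2C(=O)c3ccccc3C2=O)CC(c2cccc([N+](=O)[O-])c2)N1` gives 36% in a functional assay on the whole organism for inhibition, with Mus musculus as the target, in the writhing test, with a stated time of 15 min, at a dose of 10 mg/kg (on this read-out higher numbers stand for more inhibition at the one dose given (going by the name of the read-out) and lower numbers for less inhibition), and holds the highest of the three numbers, though compound 1 `O=C1N=C(C2C(=O)c3ccccc3C2=O)CC(c2ccccc2)N1` at 31% and compound 2 `COc1ccc(C2CC(C3C(=O)c4ccccc4C3=O)=NC(=O)N2)cc1` at 31% both lie within the scatter of it. The steps of no change at the digits printed from compound 1 to compound 2 (within the scatter), a number 5 percentage points higher from compound 1 to compound 3 (within the scatter) and a number 5 percentage points higher from compound 2 to compound 3 (within the scatter) were each within the scatter. Compound 4 `O=C1N=C(C2C(=O)c3ccccc3C2=O)CC(c2ccc([N+](=O)[O-])cc2)N1` differs from compound 3 by 4-nitrophenyl in place of 3-nitrophenyl on a saturated ring carbon. Going by the values given here, no measured step compares the two nitrophenyl placements, so the bearing of the steps is indirect: every change so far at this saturated ring carbon has stayed within the scatter. For compound 4 the expected step of a number 3 percentage points lower from compound 3 to compound 4 (within the scatter) is therefore none beyond the scatter, and compound 4 is estimated at 33% with a range of 23% to 43%.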

Compound 4, a percentage reported as inhibition, in the whole organism at one dose (the size of the read-out at that dose, not a potency): 38%
For compound 4 the middle estimate is 5 percentage points below the measured one; measured number inside the range.
By their numbers in this assay, from the lowest: compounds 1, 2, 3 and 4 (each within the scatter of the next).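

In this assay, 4-nitrophenyl in place of 3-nitrophenyl on the saturated ring carbon gives a number 2 percentage points higher from compound 3 to compound 4 (within the scatter) and so does not separate the two nitrophenyl placements. Nitro in place of methoxy gives a number 7 percentage points higher from compound 2 to compound 4 (within the scatter) and nitro in place of hydrogen gives a number 7 percentage points higher from compound 1 to compound 4 (within the scatter) so the 4-nitrophenyl compound also adds no change beyond the scatter at this position. No measurement here offers an explanation for these small differences.

Still open, from the compounds shown here alone, is whether an amine or a carboxylic acid on this phenyl ring would give a step beyond the scatter. Also open, going by these compounds, is what a longer chain in place of the phenyl ring would do.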